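From chloro to hydroxy: what compound 4 may show

The compounds below may be only part of what the source reports. "The series", "measured", "known", "first", "only" and "open" are said of these compounds alone.

Measured in an ADME assay on HEp-2 cells (Homo sapiens) for cytotoxicity, read by MTT assay, with a stated time of 72 h; on this read-out lower numbers stand for stronger inhibition and higher numbers for weaker inhibition:
Compound 1 `COc1ccc(C2=C(c3cc(OC)c(OC)c(OC)c3)C(=O)C(OC(C)=O)C2)cc1OC(C)C`: > 100 ug/mL (a limit)
Compound 2 `COc1ccc(C2=C(c3cc(OC)c(OC)c(OC)c3)C(=O)C(OC(C)=O)C2)cc1`: 18 ug/mL
Compound 3 `COc1ccc(C2=C(c3cc(OC)c(OC)c(OC)c3)C(=O)C(OC(C)=O)C2)cc1Cl`: < 1 ug/mL (a limit)

Compound 3 has the lowest reading of the three, and its steps to both others lie beyond the scatter. From the compounds shown here alone, its < 1 ug/mL is a limit and not a number, so its true distance from any neighbour remains open. Compound 4 `COc1ccc(C2=C(c3cc(OC)c(OC)c(OC)c3)C(=O)C(OC(C)=O)C2)cc1O` has hydroxy in place of chloro on an aromatic carbon, ortho to a methoxy group, turning 3-chloro-4-methoxyphenyl into 3-hydroxy-4-methoxyphenyl: hydroxy in place of chloro on an aromatic carbon.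

Going by the values given here, three measured steps concern this same place. Putting chloro in place of hydrogen gave a large drop, an at least 18-fold lower number from compound 2 to compound 3 (1.25 log units; beyond the scatter). Putting chloro in place of isopropoxy gave a larger one, an at least 100-fold lower number from compound 1 to compound 3 (2.00 log units; beyond the scatter). Hydrogen in place of isopropoxy gave a smaller drop, an at least 5.5-fold lower number from compound 1 to compound 2 (0.74 log units; beyond the scatter). The group at this place therefore moves the number widely in this assay, and chloro gave the lowest reading among the three groups tried. Among the compounds with values here, no measured compound carries hydroxy here, so the estimate remains broad. Losing the chloro of compound 3, with its < 1 ug/mL, is expected to raise the number modestly, giving an estimated at least 3.0-fold higher number from compound 3 to compound 4 (0.47 log units; beyond the scatter). For compound 4 the expected value is 3 ug/mL, with an estimated range from 0.5 ug/mL to 20 ug/mL.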

Compound 4, half-maximal inhibitory concentration: > 100 ug/mL
Compound 4: no number, only a limit; the forecaster's own chance of this, stated with the estimate: 30%; middle value at least 33-fold (1.52 log units) away from the limit.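

In this assay, exchanging chloro for hydroxy, one heavy atom for one, gave an at least 100-fold higher number from compound 3 to compound 4 (2.00 log units; beyond the scatter), so this place on the ring responds sharply even when the size of the group, counted in heavy atoms, stays the same. Hydroxy also lands on the far side of hydrogen, with an at least 5.5-fold higher number from compound 2 to compound 4 (0.74 log units; beyond the scatter); until now only isopropoxy had given a higher number than hydrogen here, and compound 4 shows that a group of a single heavy atom can do the same, so the heavy-atom count of the group does not set the order among the compounds shown. The reading of compound 4 is a limit and not a number, so how far hydroxy raises the number remains unknown: the limit of > 100 ug/mL in this assay, at which 2 of the 4 values shown sit.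

Compound 1 and compound 4 both stand as limits, and the step between them cannot be read, which leaves open whether capping the hydroxy with isopropyl changes anything at all. Also open, from the compounds shown here alone, is where other groups at this place would fall, such as fluoro or bromo, which would test how far the low reading of chloro extends, or an amine, which would test how far the high reading of hydroxy extends.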